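This account rests on a few compounds, and the source may have more. Where it says the series, first, only, none or still open, it means among the compounds named here.

Working notes on the series.

Compound 1 `C[C@@H](Oc1cc2onc(CCC(=O)O)c2cc1Cl)c1ccc(F)cn1` and compound 2 `C[C@@H](Oc1cc2onc(CCC(=O)O)c2cc1Cl)c1ccc(Cl)cn1` share one core and differ only in the halogen on the six-membered aromatic ring with one nitrogen. In an assay for inhibition of kynurenine 3-monooxygenase (Homo sapiens), read by mass spectrometry, with a stated time of 1 h (on this read-out lower numbers stand for stronger inhibition and higher numbers for weaker inhibition), compound 1 gives 3.16 nM, and in this assay compound 2 gives 3.16 nM. The step of no change at the digits printed from compound 1 to compound 2 (within the scatter) shows that chloro in place of fluoro on this aromatic carbon makes no difference within the scatter, so compound 2 stands level with compound 1 in this assay.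

Compound 3 `C[C@@H](Oc1cc2onc(CCC(=O)O)c2cc1Cl)c1ccccn1` is the next member. Its difference from compound 2 is hydrogen in place of chloro on an aromatic carbon two atoms from the ring nitrogen and para to a large group; cut one bond further out, the change reads 5-chloropyridin-2-yl to pyridin-2-yl. Going by the values given here, the only step that bears on this position is the halogen swap from compound 1 to compound 2, which was flat. Among the compounds with values here, no measured step shows what removing the halogen altogether does. Given that tolerance, the expected step of a 1.6-fold higher number from compound 2 to compound 3 (0.20 log units; within the scatter) for compound 3 is small, at most a modest weakening. The estimate for compound 3 in this assay is 5 nM, with a range from 2 nM to 15 nM.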

Compound 3, half-maximal inhibitory concentration in the kynurenine 3-monooxygenase assay: 5.01 nM
Beside the measured number, compound 3's estimate is 1.0-fold (0.00 log units) below it, within the range that was stated.
By their numbers in the kynurenine 3-monooxygenase assay, from the lowest: compounds 1, 2 and 3 (each within the scatter of the next).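

Compound 1 and compound 2 only exchanged one halogen for another; compound 3 shows that in the kynurenine 3-monooxygenase assay this position also tolerates having no halogen at all. Hydrogen in place of chloro gives a 1.6-fold higher number from compound 2 to compound 3 (0.20 log units; within the scatter) and hydrogen in place of fluoro gives a 1.6-fold higher number from compound 1 to compound 3 (0.20 log units; within the scatter) so that 5-chloropyridin-2-yl and pyridin-2-yl cannot be told apart on this read-out. The same change is not silent in a physicochemical assay for lipophilicity, read by HPLC, at pH 7.4 (on this read-out lower numbers stand for lower lipophilicity and higher numbers for higher lipophilicity), where it gives a number 0.92 log units lower from compound 2 to compound 3 (beyond the scatter) and so separates lipophilicity from inhibition at this position, with compound 3 level with compound 2 in inhibition but clearly lower in lipophilicity: the measured distribution coefficient of compound 2, 2.91, and of compound 3, 1.99, a number 0.92 log units lower (beyond the scatter). In the physicochemical assay compound 2 gives 2.91 and compound 3 gives 1.99 on this read-out.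

On these data alone, whether the tolerance extends beyond hydrogen and the two halogens remains open, since a methyl, a methoxy, a nitrile or an amine at this carbon could hold the level in the kynurenine 3-monooxygenase assay or could lose it. Also open, as far as these compounds go, is whether the position stays this forgiving when the carboxylic acid of the shared core gives way to a primary amide or a longer chain.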